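The source may hold more compounds than are shown below. What is called first, only, known or untested is meant among the compounds shown, and "the series" means these compounds.

Compound 3 `O=C1O[C@]2(CC[C@H](CNc3ccc(C(F)(F)F)cn3)CC2)CN1c1ccccn1` gives the highest of the three numbers measured in a functional assay for antagonist activity at Neuropeptide Y receptor type 5 (Homo sapiens) (on this read-out higher numbers stand for weaker inhibition and lower numbers for stronger inhibition), where compound 3 gives 1 nM. Its nearest neighbour is compound 1 `O=C1O[C@]2(CC[C@H](CNc3cnn(-c4ccccc4F)c3)CC2)CN1c1ccnnc1`, which in this assay gives 0.2 nM, and the furthest is compound 2 `O=C1O[C@]2(CC[C@H](CNc3ccc(OC4CCC4)cn3)CC2)CN1c1ccccn1`, which gives 0.159 nM. Within the data shown here, the one step between measured compounds that changes a single place is a 6.3-fold higher number from compound 2 to compound 3 (0.80 log units; beyond the scatter).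

Compound 4 `O=C1O[C@]2(CC[C@H](CNc3ccc(-c4nccs4)cn3)CC2)CN1c1ccccn1` differs from compound 3 in one place: 1,3-thiazol-2-yl in place of trifluoromethyl on an aromatic carbon. The step from compound 2 to compound 3 concerns the same aromatic carbon, and it shows that swapping the group at that carbon can move the number by a modest amount beyond the scatter. Since compound 2 carries a ring-bearing group at that carbon and gives the lowest number of the three, a ring entering in place of trifluoromethyl is expected to move the number back down, by a 2.9-fold lower number from compound 3 to compound 4 (0.46 log units; beyond the scatter). Compound 4 is therefore estimated at 0.35 nM, within a range from 0.1 nM to 1.5 nM.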

Compound 4, inhibition constant: 0.126 nM
Compound 4: middle estimate off by 2.8-fold (0.44 log units), on the high side; low and high end bracket the measured number.
By their numbers in this assay, from the lowest: compounds 4, 2 and 1 (each within the scatter of the next); then compound 3.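

In this assay, the step of a 7.9-fold lower number from compound 3 to compound 4 (0.90 log units; beyond the scatter) shows that a second ring-bearing group at this aromatic carbon also gives a clearly lower number than trifluoromethyl. The step of a 1.3-fold lower number from compound 2 to compound 4 (0.10 log units; within the scatter) lies within the scatter, so cyclobutyloxy and 1,3-thiazol-2-yl cannot be told apart here, even though one holds a five-membered aromatic ring and the other does not, and a low number at this position does not depend on one particular ring. Nothing at hand explains why these three groups fall in this order.

As far as these compounds go, it remains open whether a ring is needed at all, since an open chain such as butoxy or a small group such as methoxy could sit at this carbon. A plain phenyl or an amine there would test how much the hetero atoms of the thiazole contribute.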